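Taking the Chloro Group Off Compound 3

This account rests on a few compounds, and the source may have more. Where it says the series, first, only, none or still open, it means among the compounds named here.

Of the compounds shown here, three have been tested in an ADME assay on TERT-RPE1 cells (Homo sapiens) for cytotoxicity, read by MTT assay, with a stated time of 72 h; a higher number here means a weaker inhibitor, a lower number a stronger inhibitor. Compound 1 `COc1ccc(/C=C2/CN(C)/C(=N/c3ccc(C)cc3)S2)cc1` gives 65700 nM. Compound 2 `C=C1CN(C)/C(=N/c2ccccc2)S1` reaches only a limit of the assay, > 100000 nM. Compound 3 `COc1ccc(/C=C2\S/C(=N\c3ccc(C)c(Cl)c3)N(C)C2=O)cc1` gives 23000 nM, the lower of the two actual numbers, and its gap to compound 1 lies beyond the scatter.

Compound 4 `COc1ccc(/C=C2\S/C(=N\c3ccc(C)cc3)N(C)C2=O)cc1` has not yet been measured in this assay. It carries hydrogen in place of chloro on an aromatic carbon, so that 3-chloro-4-methylphenyl becomes 4-methylphenyl: hydrogen in place of chloro on an aromatic carbon. Going by the values given here, no measured pair of compounds shows this change on its own, so the only guide is the spread of the numbers, with compound 3 at 23000 nM and compound 1 at 65700 nM. A modest rise in the number is expected in this assay, an estimated step of a 1.7-fold higher number from compound 3 to compound 4 (0.22 log units; within the scatter), which could still prove to be within the scatter. For compound 4 the estimate is 38000 nM, with an expected range of 15000 nM to 90000 nM.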

Compound 4, half-maximal inhibitory concentration: > 100000 nM
Compound 4: only a limit was reported; the forecaster's own chance of this, stated with the estimate: 10%; middle value at least 2.6-fold (0.42 log units) from the limit.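

In this assay, this is the first comparison among the compounds shown that differs in one place only, and removing the chloro group ortho to the methyl group gives an at least 4.3-fold higher number from compound 3 to compound 4 (0.63 log units; beyond the scatter). This shows that the group on this aromatic carbon matters in this assay, with the chloro-bearing compound 3 holding the lower number. Compound 4 gives > 100000 nM, which is a limit of the assay, and the step can be read only as a bound: the limit of > 100000 nM in this assay, at which 2 of the 4 values shown sit.

The compounds shown leave open whether the lower number of compound 3 belongs to chloro in particular or would also come with another group on this carbon, such as fluoro, bromo, methoxy or an amine. They also leave open whether adding chloro to the 4-methylphenyl group on the core of compound 1 would lower its number in the same way.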